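This account rests on a few compounds, and the source may have more. Where it says the series, first, only, none or still open, it means among the compounds named here.

Measured compounds, with their values in a functional assay for inhibition, with Homo sapiens as the target; on this read-out higher numbers stand for weaker inhibition and lower numbers for stronger inhibition:

compound 1, `CCCc1nc(C)c2cnnc(SCC(=O)OCC)n12`: > 48000 nM, a limit of the assay
compound 2, `CCOC(=O)CSc1nncc2c(C)ncn12`: > 48000 nM, a limit of the assay
compound 3, `Cc1nc(C)n2c(O)nncc12`: > 48000 nM, a limit of the assay

Compound 4, `CCCc1nnc(O)n2c(C)nc(C)c12`, is not yet measured. It differs from compound 3 by propyl in place of hydrogen on an aromatic carbon. The same kind of change is found once more among the measured compounds, from compound 2 to compound 1, where it is propyl in place of hydrogen on an aromatic carbon; there it gives a step that the two limits leave unreadable from compound 2 to compound 1. The surroundings of the two places are not the same: in compound 4 the propyl sits on a six-membered aromatic ring with 3 nitrogen, next to the ring nitrogen, ortho to a fused ring and para to a hydroxy group, whereas in compound 1 it sits on a five-membered aromatic ring with 2 nitrogen, between two ring nitrogen atoms and two ring bonds from the ring atom that bears a methyl group. The difference between the core of compound 3 and the core of compound 2 is not broken down here.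

Among the measured compounds shown here, all that is known of this assay is the limit of > 48000 nM in this assay, at which 3 of the 3 values shown sit, so no step is readable from any measured pair. For compound 4 the step that the limit leaves unreadable from compound 3 to compound 4 is therefore expected to be unreadable as well, resting only on the values of compound 3 and compound 1 both being limits. Compound 4 is estimated at 60000 nM, with a range from 20000 nM to 200000 nM, most likely reported again as a limit.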

Compound 4, half-maximal inhibitory concentration: > 48000 nM
Compound 4 gave a limit, no number; the forecaster's own chance of this, stated with the estimate: 85%; the middle value does not contradict the limit.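

In this assay compound 4 gives > 48000 nM, which is a limit and not a number. No step can be read from compound 3 to compound 4, as the values of both compounds are limits: the limit of > 48000 nM in this assay, at which 4 of the 4 values shown sit.

The compounds shown leave open how large any change from propyl in place of hydrogen on an aromatic carbon is in this assay, and whether any compound of this series gives a readable value.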